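Cytotoxicity on Monocytic Cells: From Compound 3 to Compound 4

A few compounds are considered here, and "the series" means these few. Any claim that something is new, unique, unknown or untested is made for them only; others in the source may bear on it.

Compound 1, `Cc1cc(-c2ccc3[nH]c(=O)nc(-c4ccccc4)c3c2)ccn1`, in an ADME assay on THP-1 cells (Homo sapiens) for cytotoxicity, read by MTT assay, with a stated time of 72 h; on this read-out lower numbers stand for an effect already at smaller amounts and higher numbers for an effect only at larger amounts of compound: > 50000 nM, a limit of the assay.
Compound 2, `O=c1nc(-c2ccccc2)c2cc(-c3ccccc3)ccc2[nH]1`, in this assay: > 50000 nM, a limit of the assay.
Compound 3, `N#Cc1ccc(-c2ccc3[nH]c(=O)nc(-c4ccccc4)c3c2)cc1`, in this assay: > 50000 nM, a limit of the assay.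

Compound 3 therefore stands at the limit of this assay, not at a number. The same holds for the other two compounds measured, as the limit of > 50000 nM in this assay, at which 3 of the 3 values shown sit, shows. Accordingly none of the measured steps can be read: a step that the two limits leave unreadable from compound 1 to compound 2, a step that the two limits leave unreadable from compound 1 to compound 3 and a step that the two limits leave unreadable from compound 2 to compound 3 are all left unreadable by the two limits, so no size or direction is known for any change at this position.

Compound 4, `O=c1nc(-c2ccccc2)c2cc(-c3cncnc3)ccc2[nH]1`, is not yet measured. It differs from compound 3 in one place: pyrimidin-5-yl in place of 4-cyanophenyl on an aromatic carbon. Among the compounds with values here, since the steps that bear on this position are unreadable, nothing in the measured series points toward a step in either direction beyond the scatter. The expectation for compound 4 in this assay is that it, too, will sit at the limit, with an estimated a number no higher from compound 3 to compound 4 (the limit leaves the size open). On that basis compound 4 is estimated at 50000 nM, with a range from 20000 nM to 100000 nM, and a limit is expected to be reported.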

Compound 4, half-maximal effective concentration: > 50000 nM
Compound 4: only a limit was reported; the forecaster's own chance of this, stated with the estimate: 85%; the middle value sits exactly at the limit.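

In this assay compound 4 gives > 50000 nM, which is a limit of the assay. No new step can be read between compound 4 and compound 1, compound 2 or compound 3, since all of them rest on the same limit: the limit of > 50000 nM in this assay, at which 4 of the 4 values shown sit. The compounds shown leave open at what concentration, if any, cytotoxicity would appear, and whether the group at this position affects it.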